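Phenyl ether changes in one antiproliferative series

A few compounds are considered here, and "the series" means these few. Any claim that something is new, unique, unknown or untested is made for them only; others in the source may bear on it.

Measured so far:
compound 1 `Cc1nn(C)c(Oc2ccc(F)cc2)c1/C=N\CCCCCCOc1cc2oc(=O)cc(C)c2cc1Cl`: 12500 nM
compound 2 `Cc1nn(C)c(Oc2ccc(F)c(F)c2)c1/C=N\CCCCCCOc1cc2oc(=O)cc(C)c2cc1Cl`: > 25000 nM
compound 3 `Cc1nn(C)c(Oc2ccc(Br)cc2)c1/C=N\CCCCCCOc1cc2oc(=O)cc(C)c2cc1Cl`: 4630 nM

In a functional assay on HepG2 cells (Homo sapiens) for antiproliferative activity, read by MTT assay, with a stated time of 72 h (a lower number here means a stronger inhibitor, a higher number a weaker inhibitor), compound 3 gives 4630 nM, the lowest of the two numbers shown. Compound 1 gives 12500 nM. That gap reads a 2.7-fold lower number from compound 1 to compound 3 (0.43 log units; beyond the scatter). For compound 2 the value > 25000 nM is a limit of the assay and not a number (the limit of > 25000 nM in this assay, at which 1 of the 3 values shown sits).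

Compound 4 `Cc1nn(C)c(Oc2cccc(C(F)(F)F)c2)c1/C=N\CCCCCCOc1cc2oc(=O)cc(C)c2cc1Cl` differs from compound 3 by 3-(trifluoromethyl)phenyl in place of 4-bromophenyl on an oxygen on an aromatic ring. Going by the values given here, two measured steps bear on this: a 2.7-fold lower number from compound 1 to compound 3 (0.43 log units; beyond the scatter) and an at least 5.3-fold lower number from compound 2 to compound 3 (0.73 log units; beyond the scatter). Both end at the 4-bromophenyl and both lower the number; compound 4 gives the 4-bromophenyl up again. A higher number is therefore expected for compound 4, beyond the scatter, a 2.4-fold higher number from compound 3 to compound 4 (0.38 log units; beyond the scatter). Compound 4 is estimated at 11000 nM, with a range from 4000 nM to 25000 nM.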

Compound 4, half-maximal inhibitory concentration: > 25000 nM
Compound 4: a limit, no number; the forecaster's own chance of this, stated with the estimate: 20%; middle value at least 2.2-fold (0.35 log units) away from the limit.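

Compound 4 carries a limit of the assay and not a number. In this assay the 3-(trifluoromethyl)phenyl on this oxygen falls well short of the 4-bromophenyl (an at least 5.3-fold higher number from compound 3 to compound 4 (0.73 log units; beyond the scatter)), while against the 4-fluorophenyl only a floor can be given (an at least 2.0-fold higher number from compound 1 to compound 4 (0.30 log units; that floor lies within the scatter)). The step between the two limits cannot be read: the limit of > 25000 nM in this assay, at which 2 of the 4 values shown sit.

The trifluoromethyl group and its place on the ring remain unseparated here; a 4-(trifluoromethyl)phenyl or a 3-bromophenyl would separate them. As far as these compounds go, how a 4-chlorophenyl would compare with the 4-bromophenyl also stays open.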